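Methyl in Place of Hydrogen on an Aromatic Oxygen

This account rests on a few compounds, and the source may have more. Where it says the series, first, only, none or still open, it means among the compounds named here.

Measured so far in a functional assay on MDA-MB-231 cells (Homo sapiens) for cytotoxicity, read by MTT assay; a higher number here means a weaker inhibitor, a lower number a stronger inhibitor:
compound 1 `COc1ccc(-n2cc(-c3ccc(O)c(OC)c3)nn2)cc1`: > 10000 nM
compound 2 `COc1ccc(-n2cc(-c3ccc(OC)c(OC)c3)nn2)cc1`: > 100 nM
compound 3 `COc1ccc(-n2cc(-c3ccc(N)cc3)nn2)cc1O`: > 10000 nM

In this assay compound 1 gives > 10000 nM, a limit of the assay and not a number. Compound 2 gives > 100 nM, which is again a limit. The change from compound 1 to compound 2 is methyl in place of hydrogen on an oxygen on an aromatic ring, and it makes a step that the two limits leave unreadable from compound 1 to compound 2, because both ends sit on limits, the limit of > 10000 nM in this assay, at which 2 of the 3 values shown sit, and (the limit of > 100 nM in this assay, at which 1 of the 3 values shown sits). Compound 3 gives > 10000 nM, once more a limit. How the core of compound 3 differs from the core of compound 1 is not broken down here.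

Compound 4 `COc1ccc(-n2cc(-c3ccc(N)cc3)nn2)cc1OC` is yet to be measured in this assay. It differs from compound 3 by methyl in place of hydrogen on an oxygen on an aromatic ring, the same change as between compound 1 and compound 2, at the same kind of place. For compound 4 the expected step is a step that the limit leaves unreadable from compound 3 to compound 4. That expectation rests on compound 3, whose value is a limit, and on the earlier step, which the limits leave unreadable. Compound 4 is therefore estimated at 15000 nM, within 3000 nM to 60000 nM.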

Compound 4, half-maximal inhibitory concentration: > 10000 nM
Compound 4 gave a limit, no number (the forecaster's own chance of this, stated with the estimate: 60%); the middle value lies beyond the limit too.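

No step can be read from compound 3 to compound 4 in this assay, because both compounds sit on the same limit of the assay: the limit of > 10000 nM in this assay, at which 3 of the 4 values shown sit.

The compounds shown leave open what actual number any of the four would give in this assay, and so how much methyl in place of hydrogen on an oxygen on an aromatic ring changes the result.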